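The source may hold more compounds than are shown below. What is called first, only, known or untested is meant among the compounds shown, and "the series" means these compounds.

Compound 1 `O=C(Nc1ccc(-n2ncc3c(Br)cccc32)cc1)Nc1ccc(Cl)c(C(F)(F)F)c1` is the starting point. In a functional assay on HT-29 cells (Homo sapiens) for cytotoxicity, read by MTT assay, with a stated time of 72 h (a lower number here means a stronger inhibitor, a higher number a weaker inhibitor), compound 1 gives 4000 nM, the second highest of the three numbers recorded; compound 3 `O=C(Nc1ccc(-n2ncc3c(C(F)(F)F)cccc32)cc1)Nc1ccc(C(F)(F)F)cc1` gives 3300 nM, and compound 2 `O=C(Nc1ccc(-n2ncc3c(F)cccc32)cc1)Nc1ccc(Cl)c(C(F)(F)F)c1` gives 8200 nM. The new member, compound 4 `O=C(Nc1ccc(-n2ncc3cccnc32)cc1)Nc1ccc(Cl)c(C(F)(F)F)c1`, carries the change (a group of 9 heavy atoms (6 carbon, 3 nitrogen; one five-membered aromatic ring with 2 hetero atoms, one six-membered aromatic ring with 1 hetero atom) in place of a group of 10 heavy atoms (7 carbon, 2 nitrogen, 1 bromine; one five-membered aromatic ring with 2 hetero atoms, one six-membered aromatic ring of carbon only), on an aromatic carbon). Among the compounds with values here, the only measured step that touches this part of the molecule is a 2.1-fold higher number from compound 1 to compound 2 (0.31 log units; beyond the scatter), which moved the number modestly upward. Within the data shown here, a nitrogen placed in the six-membered ring of that group has no counterpart among the measured compounds, so the expectation leans on that single step. Compound 4 is therefore expected to give 6000 nM (range 2500 nM to 15000 nM), a step of a 1.5-fold higher number from compound 1 to compound 4 (0.18 log units; within the scatter) in this assay.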

Compound 4, half-maximal inhibitory concentration: > 32000 nM
Compound 4 gave a limit, no number; the forecaster's own chance of this, stated with the estimate: 10%; at least 5.3-fold (0.72 log units) between middle value and limit.
By their numbers in this assay, from the lowest: compounds 3 and 1 (each within the scatter of the next); then compound 2. At a limit, above all of these: compound 4.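

In this assay, within the data shown here, the earlier compounds showed this position only through an exchange of one halogen for another, whereas a hetero atom in the six-membered ring, with no halogen, gives an at least 8.0-fold higher number from compound 1 to compound 4 (0.90 log units; beyond the scatter) and an at least 3.9-fold higher number from compound 2 to compound 4 (0.59 log units; beyond the scatter). Both steps lie beyond the scatter, so this part of the molecule tolerates this change less well than it tolerates fluoro for bromo. Compound 4 stands at a limit, not a number: the limit of > 32000 nM in this assay, at which 1 of the 4 values shown sits.

The compounds shown do not separate the loss of the halogen from the entry of the ring nitrogen. As far as these compounds go, whether a ring nitrogen with the bromine kept, or an amine or methoxy group on the carbon ring, would restore a measurable number remains open.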